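The source may report more compounds than this note shows. Statements on the series, on what has been measured and on what is new or still open speak of the compounds shown alone.

Compound 1 `Cc1ccc2[nH]c(-c3ccc(-c4ccc(-c5ccc(N(C)C)cc5)cc4)cc3)nc2c1` and compound 2 `CN(C)c1ccc(-c2ccc(-c3ccc(-c4nc5ccccc5[nH]4)cc3)cc2)cc1` share a core and differ in one place only, hydrogen in place of methyl on an aromatic carbon. In a functional assay on Gurav cells (Homo sapiens) for inhibition, read by sulforhodamine B assay (a lower number here means a stronger inhibitor of growth, a higher number a weaker inhibitor of growth), compound 1 gives 6240 nM, while in this assay compound 2 gives 100000 nM. Among the compounds with values here, of the two numbers so far, compound 1 has the lower one, and removing the methyl gives a 16-fold higher number from compound 1 to compound 2 (1.20 log units; beyond the scatter). Compound 3 `Cc1ccc2[nH]c(-c3ccc(-c4ccc(-c5ccc(O)cc5)cc4)cc3)nc2c1` keeps the methyl of compound 1 and changes a different place: hydroxy in place of dimethylamino on an aromatic carbon. Within the data shown here, no measured pair differs at that place, so the one step known, which concerns the methyl, does not bear directly on this change; it shows only that a single change on this core can move the number far in this assay. With nothing to weigh the hydroxy against the dimethylamino, the step of a 1.3-fold higher number from compound 1 to compound 3 (0.11 log units; within the scatter) is expected to be small, and the range is kept wide enough to allow a move in either direction. In this assay compound 3 is estimated at 8000 nM, with a range from 2000 nM to 40000 nM.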

Compound 3, concentration for 50% growth inhibition: 11300 nM
The estimate for compound 3 lay 1.4-fold (0.15 log units) below the measured number; measured number inside the range.
By their numbers in this assay, from the lowest: compounds 1 and 3 (each within the scatter of the next); then compound 2.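

In this assay, the change from 4-(dimethylamino)phenyl to 4-hydroxyphenyl gives a 1.8-fold higher number from compound 1 to compound 3 (0.26 log units; within the scatter), so this assay does not separate the two groups at this place. That holds even though the groups differ in size and in what they offer: dimethylamino has 3 heavy atoms and 0 hydrogen-bond donors, while hydroxy has 1 heavy atom and 1 hydrogen-bond donor. The earlier methyl change gave a 16-fold higher number from compound 1 to compound 2 (1.20 log units; beyond the scatter), so on this core one change can lie beyond the scatter while another, at a different place, stays within it; nothing available explains this result.

Going by these compounds, two groups at one place are a thin basis, so it remains open whether a methoxy, a primary amine or a carboxylic acid on the same aromatic carbon would also stay within the scatter of compound 1. On these data alone, it is also open whether the change from dimethylamino to hydroxy would read the same on compound 2, which lacks the methyl.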